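The source may hold more compounds than are shown below. What is called first, only, known or untested is meant among the compounds shown, and "the series" means these compounds.

Compound 1 `O=C1NC(=O)/C(=C/c2ccc(OCCSc3nnc(-c4ccc(Cl)cc4)[nH]3)cc2)S1`, compound 2 `O=C1NC(=O)/C(=C/c2ccc(OCCSc3nnc(-c4ccccc4)o3)cc2)S1` and compound 3 `O=C1NC(=O)/C(=C/c2ccc(OCCSc3nnc(Cc4ccccc4)o3)cc2)S1` have been measured. In a functional assay on the whole organism (plasma, strain Wistar) with Rattus norvegicus as the target, with a stated time of 15 days, at a dose of 100 mg/kg by the oral route (on this read-out higher numbers stand for a stronger effect at the one dose given and lower numbers for a weaker effect), compound 1 gives 28.9%, compound 2 gives 20.1% and compound 3 gives 23.1%.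

Compound 3 thus stands second of the three numbers, but its gaps to compound 1 and to compound 2 both lie within the scatter, so the three read as one group. Compound 4 `O=C1NC(=O)/C(=C/c2ccc(OCCSc3nnc(-c4cccnc4)o3)cc2)S1` differs from compound 3 in one place: pyridin-3-yl in place of benzyl on an aromatic carbon. For the measured compounds named here, the only measured step that bears on this part of the molecule is a number 3 percentage points higher from compound 2 to compound 3 (within the scatter), a change within the scatter. Nothing measured covers a pyridin-3-yl group here. Compound 4 is therefore expected to move from compound 3 by no more than the scatter, a step of a number 1.1 percentage points lower from compound 3 to compound 4 (within the scatter). In this assay compound 4 is estimated at 22%, within 12% to 32%.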

Compound 4, a percentage reported as activity, at one dose (the size of the read-out at that dose, not a potency): 50.1%
Compound 4: the middle estimate sits 28.1 percentage points below what was measured; the measured number lies above the stated range.
By their numbers in this assay, from the lowest: compounds 2, 3 and 1 (each within the scatter of the next); then compound 4.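

In this assay, the group on this aromatic carbon now clearly matters: pyridin-3-yl in place of benzyl gives a number 27 percentage points higher from compound 3 to compound 4 (beyond the scatter), and pyridin-3-yl in place of phenyl gives a number 30 percentage points higher from compound 2 to compound 4 (beyond the scatter). The earlier change from phenyl to benzyl had stayed within the scatter, whereas pyridin-3-yl brings a ring nitrogen and a hydrogen-bond acceptor that benzyl lacks. No measurement here accounts for the rise. The compounds shown leave open whether pyridin-2-yl or pyridin-4-yl would match pyridin-3-yl at this position.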